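The source may report more compounds than this note shows. Statements on the series, on what has been measured and on what is new or still open speak of the compounds shown alone.

In a functional assay on Jurkat cells (Homo sapiens) (on this read-out higher numbers stand for weaker inhibition and lower numbers for stronger inhibition), compound 1 (`CC(C)[C@H](NC(=O)COc1cccc2ccccc12)C(=O)N[C@@H](CC(=O)O)C(=O)COc1ccccc1C(F)(F)F`) gives > 100000 nM, which is a limit of the assay and not a number. Compound 2 (`CC(C)[C@H](NC(=O)COc1cccc2ccccc12)C(=O)N[C@@H](CC(=O)O)C(=O)COc1cc(F)ccc1F`) gives > 100000 nM, which is also a limit and not a number. Compound 2 therefore has no exact position on the scale, and the evidence so far is the limit of > 100000 nM in this assay, at which 2 of the 2 values shown sit. For the measured compounds named here, the only measured step, a step that the two limits leave unreadable from compound 1 to compound 2, has no readable size, so it offers no real measure of how much changing this aryl group matters.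

Compound 3 (`CC(C)[C@H](NC(=O)COc1cccc2ccccc12)C(=O)N[C@@H](CC(=O)O)C(=O)COc1ccc(F)c(F)c1`) keeps the rest of the molecule and differs from compound 2 as follows: 3,4-difluorophenyl in place of 2,5-difluorophenyl on an oxygen on a saturated carbon. In words, 3,4-difluorophenyl stands in place of 2,5-difluorophenyl on an oxygen on a saturated carbon, so the same atoms are joined differently. Going by the values given here, with no sized step to draw on, no direction can be argued, and no change beyond the scatter is expected in this assay. Another limit would be the most likely report. The expected change is a number no higher from compound 2 to compound 3 (the limit leaves the size open). For compound 3, the estimated value is 100000 nM, with an expected range from 30000 nM to 300000 nM.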

Compound 3, half-maximal inhibitory concentration: > 100000 nM
Compound 3 gave a limit, no number (the forecaster's own chance of this, stated with the estimate: 75%); the middle value lies on the limit itself.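

Compound 3, like compound 1 and compound 2, gives only a limit of the assay and not a number, so no step among these three compounds can be read. The compounds shown leave open whether exchanging these substituted phenyl groups changes inhibition in this assay at all, since all that can be said is this: the limit of > 100000 nM in this assay, at which 3 of the 3 values shown sit.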